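This account rests on a few compounds, and the source may have more. Where it says the series, first, only, none or still open, it means among the compounds named here.

In a functional assay on BXPC-3 cells (Homo sapiens) for antiproliferative activity, read by MTT assay, with a stated time of 24 h (a higher number here means a weaker inhibitor, a lower number a stronger inhibitor), two amides of the shared core have been measured so far. Compound 1 (`CCn1c(C(=O)NCCCO)ccc1C(CC)(CC)c1ccc(OCS(=O)(=O)c2ccccc2)c(C)c1`) gives 26600 nM, and compound 2 (`CCn1c(C(=O)N[C@@H](CO)CCCO)ccc1C(CC)(CC)c1ccc(OCS(=O)(=O)c2ccccc2)c(C)c1`) gives 16400 nM. Within the data shown here, these values lie within the scatter of each other, so compound 2 cannot be ranked against the only other measured compound.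

Compound 3 (`CCn1c(C(=O)N[C@@H](C)C(=O)O)ccc1C(CC)(CC)c1ccc(OCS(=O)(=O)c2ccccc2)c(C)c1`) has yet to be measured. It carries 1-carboxyethyl on the amide-type nitrogen, and the change is a group of 5 heavy atoms (3 carbon, 2 oxygen; no ring) in place of a group of 7 heavy atoms (5 carbon, 2 oxygen; no ring), on an amide-type nitrogen. One measured step also alters the group on that nitrogen, and it stayed within the scatter: a 1.6-fold lower number from compound 1 to compound 2 (0.21 log units; within the scatter). Among the measured compounds shown here, no measured compound carries 1-carboxyethyl, so this single step is limited evidence. On that basis, no step beyond the scatter is expected in this assay. The expected change is a 1.2-fold higher number from compound 2 to compound 3 (0.09 log units; within the scatter). For compound 3 the estimated value is 20000 nM, with an expected range from 8000 nM to 50000 nM.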

Compound 3, half-maximal inhibitory concentration: 20800 nM
Compound 3: middle estimate off by 1.0-fold (0.02 log units), on the low side, within the range that was stated.
By their numbers in this assay, from the lowest: compounds 2, 3 and 1 (each within the scatter of the next).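

In this assay, placing 1-carboxyethyl on the amide-type nitrogen gives a 1.3-fold higher number from compound 2 to compound 3 (0.10 log units; within the scatter) and putting the same group in place of 3-hydroxypropyl gives a 1.3-fold lower number from compound 1 to compound 3 (0.11 log units; within the scatter) at this position. The earlier compounds shown here carried only hydroxyl-bearing chains on this nitrogen, and compound 3 shows that a group with a carboxylic acid also leaves the number within the scatter of both, so the three compounds cannot be ranked. Nothing available explains why the numbers stay so close. From the compounds shown here alone, whether an amine, a methyl ester of the acid or a ring-bearing group on this nitrogen would move the number beyond the scatter remains open. So does the effect of the opposite configuration at the defined stereocentre of 1-carboxyethyl.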